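Methyl on the Ring Nitrogen: Compound 3 Expected

A few compounds are considered here, and "the series" means these few. Any claim that something is new, unique, unknown or untested is made for them only; others in the source may bear on it.

Measured compounds:
compound 1, `CS(=O)(=O)NCCN1CCC(CNC(=O)c2cc(Cl)cc3[nH]cnc23)CC1`, 0.11 nM
compound 2, `CC(C)CN1CCC(CNC(=O)c2cc(Cl)cc3[nH]cnc23)CC1`, 0.29 nM

Both were tested in an assay on membranes from striatum for binding affinity to 5-hydroxytryptamine receptor 4 (Rattus norvegicus); a higher number here means a weaker inhibitor, a lower number a stronger inhibitor. Among the two numbers, compound 2 stands highest; its nearest neighbour is compound 1, and the step of a 2.6-fold higher number from compound 1 to compound 2 (0.42 log units; beyond the scatter) is modest but beyond the scatter. That step swaps one group on a saturated chain carbon bound to the ring amine nitrogen, far from the fused aromatic rings.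

Compound 3, `CC(C)CN1CCC(CNC(=O)c2cc(Cl)cc3c2ncn3C)CC1`, keeps everything of compound 2 and differs only by methyl in place of hydrogen on an aromatic nitrogen. For the measured compounds named here, no measured pair touches this ring nitrogen, so the one known step gives no direct guide; it only shows that the scaffold tolerates a modest change elsewhere while staying very strong. With nothing pointing either way, the expectation is a step not clearly beyond the scatter, perhaps a slight rise in the number: compound 3 is expected to show a 1.4-fold higher number from compound 2 to compound 3 (0.14 log units; within the scatter).

The estimate for compound 3 in this assay is 0.4 nM, with a range from 0.1 nM to 1.6 nM.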

Compound 3, inhibition constant: 2.2 nM
Compound 3: middle estimate off by 5.5-fold (0.74 log units), on the low side; the measured number lies above the stated range.
By their numbers in this assay, from the lowest: compound 1; then compound 2; then compound 3.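

In this assay, putting methyl in place of hydrogen on an aromatic nitrogen gives a 7.6-fold higher number from compound 2 to compound 3 (0.88 log units; beyond the scatter), so a single added carbon on this ring nitrogen weakens binding measurably. This step is larger than the only earlier one, a 2.6-fold higher number from compound 1 to compound 2 (0.42 log units; beyond the scatter), which changed a group on a saturated chain carbon bound to the ring amine nitrogen, so in this small set the aromatic nitrogen is the more sensitive of the two places. Nothing available explains why the number rises at this position, and the result alone cannot separate the loss of the hydrogen from the arrival of the methyl.

The compounds shown leave open whether an ethyl or a longer chain on the same nitrogen would raise the number further, or whether a chain ending in a hydroxyl or an amine would behave differently. They also leave open whether the same methyl change would cost as much with the (methanesulfonamido)methyl end of compound 1 in place, since the step has been read only with the isopropyl end of compound 2.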